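The compounds below may be only part of what the source reports. "The series", "measured", "known", "first", "only" and "open" are said of these compounds alone.

Measured compounds:
compound 1, `CCn1c(C(=O)NCC#N)ccc1C(CC)(CC)c1ccc(OCCC(O)(CC)CC)c(C)c1` — 1080 nM
compound 2, `CCn1c(C(=O)NC(CC(=O)O)C(=O)OC)ccc1C(CC)(CC)c1ccc(OCCC(O)(CC)CC)c(C)c1` — 26 nM

Within the data shown here, in an assay on cells for agonist activity at vitamin D3 receptor (Homo sapiens), with a stated time of 96 h (on this read-out lower numbers stand for an effect already at smaller amounts and higher numbers for an effect only at larger amounts of compound), compound 2 stands with the lowest of the two numbers, and its only neighbour is compound 1, which lies a 42-fold lower number from compound 1 to compound 2 (1.62 log units; beyond the scatter) away. Compound 3, `CCC(C)C(CO)NC(=O)c1ccc(C(CC)(CC)c2ccc(OCCC(O)(CC)CC)c(C)c2)n1CC`, is not yet measured and differs from compound 2 by a group of 7 heavy atoms (6 carbon, 1 oxygen; no ring) in place of a group of 9 heavy atoms (5 carbon, 4 oxygen; no ring), on an amide-type nitrogen. Among the measured compounds shown here, only one measured step bears on this position: the step from compound 1 to compound 2, a 42-fold lower number from compound 1 to compound 2 (1.62 log units; beyond the scatter), which shows that a change on the amide-type nitrogen can move this assay by a large amount. The group entering compound 3 shares only the hydroxyl with the group that leaves, so a step upward in number, beyond the scatter but smaller than the measured one, is expected, a 5.8-fold higher number from compound 2 to compound 3 (0.76 log units; beyond the scatter). Compound 3 is therefore estimated at 150 nM in this assay, within a range of 30 nM to 800 nM.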

Compound 3, half-maximal effective concentration: 450 nM
Estimate against measurement, compound 3: 3.0-fold (0.48 log units) below; the range from low to high includes it.
By their numbers in this assay, from the lowest: compound 2; then compound 3; then compound 1.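

In this assay the amide-type nitrogen proves sensitive in the upward direction too: putting 1-(hydroxymethyl)-2-methylbutyl on it gives a 17-fold higher number from compound 2 to compound 3 (1.24 log units; beyond the scatter) and so loses most of what the group in compound 2 had gained. Measured from the cyanomethyl end, the same change gives only a 2.4-fold lower number from compound 1 to compound 3 (0.38 log units; beyond the scatter) and remains a modest step, so a larger group on this nitrogen does not by itself bring the number down to that of compound 2. No measured property is available to explain either step.

The compounds shown leave open whether the carboxylic acid or the methyl ester in compound 2 carries its low number, which a group holding only one of them would separate. They also leave open what the hydroxyl in compound 3 contributes, which a plain alkyl chain or an amine in its place would test.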